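The compounds below may be only part of what the source reports. "The series", "measured", "known", "first", "only" and "open" are said of these compounds alone.

Measured in an ADME assay on microsomes from liver (Homo sapiens) for metabolic stability, tested at 2.5 uM; on this read-out lower numbers stand for slow clearance and higher numbers for fast clearance:
compound 1 `COc1ccc(-c2c(S(=O)(=O)c3cc(F)cc(F)c3)cnc3c(F)cccc23)cc1`: 2.59 mL/min
compound 2 `O=S(=O)(c1cc(Cl)cc(Cl)c1)c1cnc2cc(F)ccc2c1-c1ccccc1F`: 0.93 mL/min
compound 3 `O=S(=O)(c1ccc(F)c(F)c1)c1cnc2cc(F)ccc2c1-c1ccccc1F`: 0.79 mL/min

Compound 2 stands second highest of the three numbers shown; its nearest neighbour is compound 3, a step of a 1.2-fold lower number from compound 2 to compound 3 (0.07 log units; within the scatter), within the scatter, while compound 1 sits furthest from it, beyond the scatter. Compound 4 `O=S(=O)(c1cc(Cl)cc(Cl)c1)c1cnc2cc(F)ccc2c1-c1cccc(F)c1` is not yet measured. It differs from compound 2 in one place: 3-fluorophenyl in place of 2-fluorophenyl on an aromatic carbon. Among the measured compounds shown here, no measured step touches this group; the one single-place step known, the change from compound 2 to compound 3 on the sulfonyl sulfur, concerns another part of the structure and is within the scatter. For compound 4 the expectation is therefore a step of a 1.0-fold higher number from compound 2 to compound 4 (0.01 log units; within the scatter), none beyond the scatter. Compound 4 is estimated at 0.95 mL/min, range 0.5 mL/min to 1.9 mL/min.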

Compound 4, intrinsic clearance in a liver preparation (reported as CLH), per the amount of preparation that the assay uses: 0.41 mL/min
For compound 4 the middle estimate is 2.3-fold (0.36 log units) above the measured one; the measured number lies below the stated range.
By their numbers in this assay, from the lowest: compounds 4, 3 and 2 (each within the scatter of the next, the first and the last beyond it); then compound 1.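

In this assay, among the compounds shown here, shifting the fluorine on this phenyl ring, with the atoms unchanged, gives a 2.3-fold lower number from compound 2 to compound 4 (0.36 log units; beyond the scatter) and so is the first single-place step beyond the scatter. The sulfonyl change, a 1.2-fold lower number from compound 2 to compound 3 (0.07 log units; within the scatter) by contrast, stays within it. The data available offer no explanation for this difference between isomers.

Still open, as far as these compounds go, is whether the same step holds with the 3,4-difluorophenyl group of compound 3 on the sulfonyl sulfur. Also open, from the compounds shown here alone, is how a nitrile or an amine in place of the fluorine on this ring would read.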